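This account rests on a few compounds, and the source may have more. Where it says the series, first, only, none or still open, it means among the compounds named here.

Working notes on the series. Three compounds carry a measurement in an assay on CHO-K1 cells for agonist activity at Orexin receptor type 2 (Homo sapiens), read by a luciferase reporter (on this read-out lower numbers stand for an effect already at smaller amounts and higher numbers for an effect only at larger amounts of compound), so far, and all three return a limit rather than a number. Compound 1 `COc1ccccc1C(=O)NCCNc1cccc(NS(=O)(=O)c2cc(-c3cccc(N)c3)ccc2OC)c1` in this assay gives > 1000 nM, which is a limit of the assay. Compound 2 `COc1ccccc1C(=O)NCCNc1cccc(NS(=O)(=O)c2cc(-c3cccc(F)c3)ccc2OC)c1` in this assay gives > 10000 nM, again a limit. Going by the values given here, the only pair differing in one place is the change from amino to fluoro on the aromatic carbon, a step that the two limits leave unreadable from compound 1 to compound 2; with both ends at a limit, nothing can be read from it. Compound 3 `COc1ccc(-c2cccc(C(=O)N(C)C)c2)cc1S(=O)(=O)Nc1cccc(NCCNC(=O)c2ccccc2)c1` in this assay gives > 10000 nM, also a limit. Compound 3 therefore stands, like the two others, without a number: one value sits at the limit of > 1000 nM in this assay, at which 1 of the 3 values shown sits, and two values sit at the limit of > 10000 nM in this assay, at which 2 of the 3 values shown sit.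

Compound 4 `COc1ccc(-c2cccc(C(=O)N(C)C)c2)cc1S(=O)(=O)Nc1cccc(NCCNC(=O)c2ccccc2C)c1` is not yet measured. It differs from compound 3 by methyl in place of hydrogen on an aromatic carbon. Among the compounds with values here, no measured step bears on this change, and the one step available, from compound 1 to compound 2, is itself unreadable. Within the data shown here, with compound 3 at a limit and no step to carry over, no shift beyond the scatter is expected; the step from compound 3 to compound 4 is estimated as a step that the limit leaves unreadable from compound 3 to compound 4. Compound 4 is therefore expected to give about 15000 nM in this assay, in the range 5000 nM to 50000 nM, most likely reported again as a limit.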

Compound 4, half-maximal effective concentration: 800 nM
Compound 4: the middle estimate sits 19-fold (1.27 log units) above what was measured, and the stated range ends above it.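

In this assay, going by these compounds alone, methyl in place of hydrogen on an aromatic carbon, ortho to a large group, gives the only readable step so far: an at least 12-fold lower number from compound 3 to compound 4 (1.09 log units; beyond the scatter). Compound 3 stands at a limit, so the size of this step is tied to that limit and is not a gap between two numbers: the limit of > 10000 nM in this assay, at which 2 of the 4 values shown sit. This turns phenyl into 2-methylphenyl on the benzamido side and makes compound 4 the only compound shown with a number, whereas the amino to fluoro change elsewhere on the molecule, which cannot be read, gave no information about this ring.

Going by these compounds, whether ethyl, a chlorine atom or a carboxylic acid on the same aromatic carbon would keep, extend or lose this shift remains open. Within the data shown here, only one pair carries this change, so it also remains open whether the methyl gives a similar step on a compound that differs elsewhere, and what lies behind the step cannot be told from these values.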